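Removing a Methyl Group: Expected Effect on Antiproliferative Potency

The source may hold more compounds than are shown below. What is called first, only, known or untested is meant among the compounds shown, and "the series" means these compounds.

Compound 1 `COc1cccc(CNCc2c(C(=O)O)n(Cc3ccc(C)cc3)c3ccccc23)c1` gives 21500 nM in a functional assay on Bel-7402 cells (Homo sapiens) for antiproliferative activity, read by MTT assay, with a stated time of 72 h; a lower number here means a stronger inhibitor, a higher number a weaker inhibitor.
Compound 2 `COc1cccc(CNCc2c(C(=O)O)n(Cc3ccc(C)cc3)c3cc(C)ccc23)c1` gives 5670 nM in this assay.
Compound 3 `COc1ccc(Cn2c(C(=O)O)c(CNCc3ccc(O)c(OC)c3)c3ccc(C)cc32)cc1` gives 13300 nM in this assay.

Compound 2 and compound 1 share a core and differ in one place: hydrogen in place of methyl on an aromatic carbon. This change gives a 3.8-fold higher number from compound 2 to compound 1 (0.58 log units; beyond the scatter), a weakening of inhibition that lies beyond the usual scatter. Compound 3 has a different core, and the difference between the two cores is not broken down here. Its number in this assay is close to that of compound 1, within the usual scatter, while it is higher than that of compound 2.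

Compound 4 `COc1ccc(Cn2c(C(=O)O)c(CNCc3ccc(O)c(OC)c3)c3ccccc32)cc1` is the unmeasured partner of compound 3. The change between them is hydrogen in place of methyl on an aromatic carbon, the same change as from compound 2 to compound 1, at a place described in identical terms. The step from compound 3 to compound 4 in this assay is expected to be a 3.0-fold higher number from compound 3 to compound 4 (0.48 log units; beyond the scatter), because the same change gave a 3.8-fold higher number from compound 2 to compound 1 (0.58 log units; beyond the scatter). On this basis compound 4 is estimated at 40000 nM, with a likely range from 15000 nM to 110000 nM.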

Compound 4, half-maximal inhibitory concentration: > 50000 nM
Compound 4 ended at the assay's limit (the forecaster's own chance of this, stated with the estimate: 15%); middle value at least 1.2-fold (0.09 log units) from the limit.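

Compound 4 gives > 50000 nM in this assay, and this is a limit of the assay, not a number. On the second core, hydrogen in place of methyl on an aromatic carbon gives an at least 3.7-fold higher number from compound 3 to compound 4 (0.57 log units; beyond the scatter), so in these two pairs the change weakens inhibition in the same direction and by more than the usual scatter. This shows that the loss of the methyl group carried over from one core to the other in these two cases, but it does not show that the size of the effect is the same on both: the same change on two cores in this assay, a 3.8-fold higher number (0.58 log units; beyond the scatter) from compound 2 to compound 1 and an at least 3.7-fold higher number (0.57 log units; beyond the scatter) from compound 3 to compound 4; the limit leaves it open whether they differ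

Only methyl and hydrogen appear at this place in the compounds shown, so what an ethyl group, a chlorine atom or an amine would do there remains open. Also open, going by these compounds, are how far compound 4 lies past its limit and whether the same change would weaken inhibition on any core beyond these two.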